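Leucine-type side chain on the Boc-protected amide series

The compounds below may be only part of what the source reports. "The series", "measured", "known", "first", "only" and "open" are said of these compounds alone.

Compound 1 `CCCCCC(=O)c1ccc(OCCCN2CCN(C(=O)[C@@H](C)NC(=O)OC(C)(C)C)CC2)cc1` gives 10700 nM in an assay for binding affinity to histamine H2 receptor (Homo sapiens) (on this read-out lower numbers stand for stronger inhibition and higher numbers for weaker inhibition), the lower of the two numbers at hand. Compound 2 `CCCCCC(=O)c1ccc(OCCCN2CCN(C(=O)[C@@H](C)N)CC2)cc1` gives 40700 nM in this assay, with a 3.8-fold higher number from compound 1 to compound 2 (0.58 log units; beyond the scatter). Compound 3 `CCCCCC(=O)c1ccc(OCCCN2CCN(C(=O)[C@@H](CC(C)C)NC(=O)OC(C)(C)C)CC2)cc1` differs from compound 1 by isopropyl in place of hydrogen on a saturated chain carbon, two bonds along the chain from an amide-type nitrogen and a carbonyl carbon. Among the compounds with values here, no measured step touches this change; the only step seen concerns the carbamate, not the chain carbon. For compound 3 the expected step is therefore no change at the digits printed from compound 1 to compound 3 (within the scatter), none beyond the scatter. Compound 3 is estimated at 10700 nM in this assay, within 3500 nM to 32000 nM.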

Compound 3, inhibition constant: 4470 nM
Compound 3: the middle estimate sits 2.4-fold (0.38 log units) above what was measured, and the stated range covers the measured number.
By their numbers in this assay, from the lowest: compound 3; then compound 1; then compound 2.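

In this assay, this chain carbon responds to substitution: methyl to isobutyl, with isopropyl in place of hydrogen, gives a 2.4-fold lower number from compound 1 to compound 3 (0.38 log units; beyond the scatter), so the side chain matters as well as the carbamate. The step is modest and rests on a single pair of compounds. Nothing at hand explains the shift.

Going by these compounds, whether a longer chain, a phenyl ring or a carboxylic acid at this carbon would lower the number further remains open. Also open, on these data alone, is whether the isobutyl change carries over to the free amine of compound 2.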